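This account rests on a few compounds, and the source may have more. Where it says the series, first, only, none or still open, it means among the compounds named here.

Of the compounds shown here, three have been measured so far in a functional assay on MDA-MB-231 cells (Homo sapiens) for antiproliferative activity, read by sulforhodamine B assay, with a stated time of 48 h; a higher number here means a weaker inhibitor of growth, a lower number a stronger inhibitor of growth. Compound 1 `Cc1cc2c(cc1C)C(Cl)=C(C(=O)NNC(=S)Nc1ccccc1)CCC2` gives 3140 nM, compound 2 `Cc1cc2c(cc1C)C(Cl)=C(c1nnc(S)n1-c1ccccc1)CCC2` gives 2640 nM, and compound 3 `ClC1=C(c2nnc(-c3ccccc3)o2)CCCc2ccccc21` gives 1970 nM. The number for compound 3 lies within the usual scatter of both others, so the three cannot be ranked. Compound 4 `O=[N+]([O-])c1ccc(-c2nnc(C3=C(Cl)c4ccccc4CCC3)o2)cc1` differs from compound 3 in one place: nitro in place of hydrogen on an aromatic carbon, with nitro in place of hydrogen on an aromatic carbon, para to a large group. Within the data shown here, no measured pair differs in only one place, so the data offer no guide to such a step, and no shift beyond the scatter is expected in this assay. The expected change is small: a 1.1-fold lower number from compound 3 to compound 4 (0.04 log units; within the scatter). For compound 4 the estimated value is 1800 nM, with an expected range from 700 nM to 4500 nM.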

Compound 4, concentration for 50% growth inhibition: 3280 nM
Beside the measured number, compound 4's estimate is 1.8-fold (0.26 log units) below it, within the range that was stated.
By their numbers in this assay, from the lowest: compounds 3, 2, 1 and 4 (each within the scatter of the next).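

Putting nitro in place of hydrogen on an aromatic carbon, para to a large group, gives a 1.7-fold higher number from compound 3 to compound 4 (0.22 log units; within the scatter) in this assay. Among these compounds, this is the first pair that differs in only one place, and it shows that this position can carry nitro, with its three heavy atoms, without a shift beyond the scatter.

As far as these compounds go, whether an amine, a methoxy group or a carboxylic acid at the same place would also stay within the scatter remains open. No measured property of these compounds bears on this result.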